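The source may report more compounds than this note shows. Statements on the series, on what has been measured and on what is new or still open speak of the compounds shown alone.

Measured compounds and their values:

Compound 1, `CC(C)CCCOc1cccc(O)c1C(=O)/C=C/c1ccc(O)cc1`, gives 11600 nM in a functional assay on HCT-15 cells (Homo sapiens) for antiproliferative activity, read by sulforhodamine B assay; on this read-out higher numbers stand for weaker inhibition of growth and lower numbers for stronger inhibition of growth.
Compound 2, `CC(C)CCOc1cccc(O)c1C(=O)/C=C/c1ccc(O)cc1`, gives 10600 nM in this assay.
Compound 3, `CCC(CC)COc1cccc(O)c1C(=O)/C=C/c1ccc(O)cc1`, gives 3420 nM in this assay.

Compound 1 stands at the highest number of the three, meaning the weakest growth inhibition. Compound 2 lies close to it, with a 1.1-fold lower number from compound 1 to compound 2 (0.04 log units; within the scatter), so the two cannot be told apart. Compound 3 is set apart from both, with a 3.4-fold lower number from compound 1 to compound 3 (0.53 log units; beyond the scatter) and a 3.1-fold lower number from compound 2 to compound 3 (0.49 log units; beyond the scatter), and so shows the strongest inhibition among the three.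

Compound 4, `CC(C)COc1cccc(O)c1C(=O)/C=C/c1ccc(O)cc1`, has not yet been measured. It differs from compound 1 in one place: isopropyl in place of isopentyl on a saturated chain carbon bound to an oxygen on an aromatic ring. Two kinds of measured steps bear on this. Shortening the chain by one carbon further out, as from compound 1 to compound 2, left the number within the scatter. Changing the group on the saturated chain carbon bound to the aromatic oxygen, as in the steps to compound 3, lowered the number modestly. The change to compound 4 both shortens the chain and alters the group at that carbon, so a small to modest lowering of the number is expected, though a step within the scatter cannot be ruled out.

Compound 4 is therefore expected to give about 7000 nM in this assay, between 3000 nM and 16000 nM, which would mean an expected step of a 1.7-fold lower number from compound 1 to compound 4 (0.22 log units; within the scatter).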

Compound 4, concentration for 50% growth inhibition: 2600 nM
The estimate for compound 4 lay 2.7-fold (0.43 log units) above the measured number; the whole stated range lies above it.
By their numbers in this assay, from the lowest: compounds 4 and 3 (each within the scatter of the next); then compounds 2 and 1 (each within the scatter of the next).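

The sharp change in this series comes at the last shortening, not spread evenly along the chain: in this assay the first shortening gave a 1.1-fold lower number from compound 1 to compound 2 (0.04 log units; within the scatter), whereas going on to the isobutyl chain of compound 4 gave a 4.5-fold lower number from compound 1 to compound 4 (0.65 log units; beyond the scatter) and a 4.1-fold lower number from compound 2 to compound 4 (0.61 log units; beyond the scatter), both towards stronger inhibition of growth. Length alone does not sort these compounds, since a 1.3-fold lower number from compound 3 to compound 4 (0.12 log units; within the scatter) shows that compound 4 and compound 3 cannot be told apart, although the change between them swaps pentan-3-yl for the smaller isopropyl on the saturated chain carbon bound to the aromatic oxygen. Nothing available explains why the two longer chains sit together at the weaker end while these two sit together at the stronger end.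

The compounds shown leave open whether a still shorter chain, such as ethyl or methyl, on that oxygen would lower the number further or raise it again. They also leave open how a ring such as cyclohexyl, or an amine or a carboxylic acid at the chain end, would behave in this assay.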